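Swapping Halogens on a Metabolically Stable Scaffold

The source may report more compounds than this note shows. Statements on the series, on what has been measured and on what is new or still open speak of the compounds shown alone.

Compound 2 `Nc1nc(NCCNc2ncc(-c3ncc[nH]3)c(-c3cc(F)ccc3F)n2)ccc1[N+](=O)[O-]` carries a 2,5-difluorophenyl group on an aromatic carbon of the shared core. In an ADME assay on microsomes from liver (Rattus norvegicus) for metabolic stability (a lower number here means that the compound disappears faster, a higher number that the compound lasts longer), compound 2 gives > 0.5 h, and this is a limit of the assay rather than a measured number. Two neighbouring compounds were tested in this assay as well. Compound 1 `Clc1ccc(-c2nc(NCCNc3ccccn3)ncc2-c2ncc[nH]2)c(Cl)c1` gives > 0.5 h, which is likewise a limit. Compound 3 `Nc1nc(NCCNc2ncc(-c3ncc[nH]3)c(-c3ccc(F)cc3Br)n2)ccc1[N+](=O)[O-]` gives > 0.5 h, once more a limit. For the measured compounds named here, the only measured step that changes the same ring, a step that the two limits leave unreadable from compound 2 to compound 3, cannot be read because of the limit of > 0.5 h in this assay, at which 3 of the 3 values shown sit. So nothing is known here about how far any of these compounds really lasts beyond that point.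

Compound 4 `Nc1nc(NCCNc2ncc(-c3ncc[nH]3)c(-c3ccc(Br)cc3Cl)n2)ccc1[N+](=O)[O-]` is not yet measured. It differs from compound 2 in one place: 4-bromo-2-chlorophenyl in place of 2,5-difluorophenyl on an aromatic carbon. Going by the values given here, the only step that bears on this exchange is the one from compound 2 to compound 3, and its size is hidden by the limit, so no direction can be drawn from it. The plainest expectation is that compound 4 will again reach the limit, like the three compounds already measured. Compound 4 is therefore expected to give about 1 h in this assay, with a range from 0.5 h to 3 h. This estimate means an expected step that the limit leaves unreadable from compound 2 to compound 4.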

Compound 4, half-life: > 0.5 h
Compound 4: only a limit was reported (the forecaster's own chance of this, stated with the estimate: 80%); the middle value does not contradict the limit.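

The steps from compound 2 and from compound 3 to compound 4 in this assay cannot be read, because these values share one limit of the assay: the limit of > 0.5 h in this assay, at which 4 of the 4 values shown sit.

From the compounds shown here alone, how long any of the four compounds lasts beyond that limit, and whether the different phenyl groups on the shared core change this at all, stays open.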